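Leucine-type side chain of the amide: shortening the branched chain

A few compounds are considered here, and "the series" means these few. Any claim that something is new, unique, unknown or untested is made for them only; others in the source may bear on it.

Measured so far in an assay on isolated protein for inhibition of Rho-associated protein kinase 2 (Homo sapiens); a higher number here means a weaker inhibitor, a lower number a stronger inhibitor:
compound 1, `CC(C)C[C@@H](N)C(=O)Nc1cc2cc[nH]c(=O)c2cc1Cl`, 19 nM
compound 2, `CC(C)(C)C[C@H](N)C(=O)Nc1cc2cc[nH]c(=O)c2cc1Cl`, 845 nM
compound 3, `CC(C)C[C@H](N)C(=O)Nc1cc2cc[nH]c(=O)c2cc1Cl`, 340 nM

Compound 1 gives the lowest number of the three; compound 3 is nearest with an 18-fold higher number from compound 1 to compound 3 (1.25 log units; beyond the scatter), and compound 2 furthest with a 44-fold higher number from compound 1 to compound 2 (1.65 log units; beyond the scatter). Compound 4, `CC(C)[C@H](N)C(=O)Nc1cc2cc[nH]c(=O)c2cc1Cl`, carries 1-amino-2-methylpropyl in place of 1-amino-3-methylbutyl on a carbonyl carbon. For the measured compounds named here, two measured steps bear on the change. Compound 1 to compound 2 alters the same side chain and costs potency heavily, and compound 1 to compound 3 shows the stereocentre alone costs heavily, which is explained by the fact that compounds 1 and 3 differ only in the configuration as drawn. A side-chain change at this position is therefore expected to weaken binding, though less severely than the larger group of compound 2. Compound 4 is expected to give 120 nM, within 30 nM to 500 nM, a step of a 6.3-fold higher number from compound 1 to compound 4 (0.80 log units; beyond the scatter).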

Compound 4, half-maximal inhibitory concentration: 12 nM
Compound 4: middle estimate off by 10-fold (1.00 log units), on the high side; the whole stated range lies above it.
By their numbers in this assay, from the lowest: compounds 4 and 1 (each within the scatter of the next); then compound 3; then compound 2.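

Shortening the chain to 1-amino-2-methylpropyl is tolerated in this assay, with a 1.6-fold lower number from compound 1 to compound 4 (0.20 log units; within the scatter), so a side-chain change at this carbon does not in itself cost potency. The steps of a 28-fold lower number from compound 3 to compound 4 (1.45 log units; beyond the scatter) and a 70-fold lower number from compound 2 to compound 4 (1.85 log units; beyond the scatter) are both large, so the losses seen earlier do not extend to every change at this position. Nothing measured here accounts for this result. Open, on these data alone, is whether the opposite configuration of the 1-amino-2-methylpropyl group loses potency in the same way, and whether a cyclopropyl or straight propyl chain on this carbon keeps it.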